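The source may report more compounds than this note shows. Statements on the series, on what has been measured and on what is new or still open speak of the compounds shown alone.

Measured so far:
compound 1 `CC1=C(/C=C/C(C)=C/C=C/C(C)=C\C(=O)Nc2ccccc2)C(C)(C)CCC1n1ccnc1` — 1730 nM
compound 2 `CC1=C(/C=C/C(C)=C/C=C/C(C)=C\C(=O)Nc2ccc(O)cc2)C(C)(C)CCC1n1ccnc1` — 3890 nM
compound 3 `CC1=C(/C=C/C(C)=C/C=C/C(C)=C\C(=O)NCc2ccc(O)cc2)C(C)(C)CCC1n1ccnc1` — 2450 nM

All three were read in a functional assay on SK-BR-3 cells (Homo sapiens) for inhibition, read by MTT assay; on this read-out lower numbers stand for stronger inhibition of growth and higher numbers for weaker inhibition of growth. Compound 4 `CC1=C(/C=C/C(C)=C/C=C/C(C)=C\C(=O)NCc2ccccc2)C(C)(C)CCC1n1ccnc1` is not yet measured there.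

Compound 3 differs from compound 2 by 4-hydroxybenzyl in place of 4-hydroxyphenyl on an amide-type nitrogen; that pair shows a 1.6-fold lower number from compound 2 to compound 3 (0.20 log units; within the scatter). Compound 1 and compound 3 differ at the amide nitrogen and stand a 1.4-fold higher number from compound 1 to compound 3 (0.15 log units; within the scatter) apart.

The change from compound 3 to compound 4 is hydrogen in place of hydroxy on an aromatic carbon. The same change, made earlier from compound 2 to compound 1, is hydrogen in place of hydroxy on an aromatic carbon, and there it gave a 2.2-fold lower number from compound 2 to compound 1 (0.35 log units; beyond the scatter). The place of the change reads the same in both pairs; only the cores differ, as given above.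

On that single precedent, a step of about a 2.0-fold lower number from compound 3 to compound 4 (0.31 log units; beyond the scatter) is expected in this assay for compound 4. Compound 4 is therefore estimated at 1200 nM, with a likely range from 600 nM to 2500 nM.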

Compound 4, concentration for 50% growth inhibition: 10700 nM
Beside the measured number, compound 4's estimate is 8.9-fold (0.95 log units) below it; measured number outside the range, above it.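

In this assay, the change of hydroxy to hydrogen does not carry from one core to the other, and its direction reverses: the same change on two cores in this assay, a 2.2-fold lower number (0.35 log units; beyond the scatter) from compound 2 to compound 1 and a 4.4-fold higher number (0.64 log units; beyond the scatter) from compound 3 to compound 4, 9.8-fold (0.99 log units) apart, beyond the scatter of two such steps

On the benzyl amide the change gives a 4.4-fold higher number from compound 3 to compound 4 (0.64 log units; beyond the scatter), and compound 4 also stands apart in the steps at the amide nitrogen, with a 2.8-fold higher number from compound 2 to compound 4 (0.44 log units; beyond the scatter) and a 6.2-fold higher number from compound 1 to compound 4 (0.79 log units; beyond the scatter). These pairs show that the outcome of this change differs with the group on the amide nitrogen in these four compounds, but they do not show why, and one pair per core gives no rule for further cores.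

Open, from the compounds shown here alone, is whether a methoxy group or an amine in place of the hydroxy would follow either pattern. Going by these compounds, a longer chain in place of benzyl on the amide nitrogen also remains open.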